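The source may hold more compounds than are shown below. What is called first, only, known or untested is meant among the compounds shown, and "the series" means these compounds.

Compound 2 `COc1cc(/C=C/C(=O)OCCSc2nc(-c3ccc(S(C)(=O)=O)cc3)n(-c3ccc(C(F)(F)F)cc3)n2)ccc1OC(C)=O` sits at the lower of the two numbers recorded so far in a functional assay on PC-3 cells (Homo sapiens) for antiproliferative activity, read by MTT assay, with a stated time of 72 h (a higher number here means a weaker inhibitor, a lower number a stronger inhibitor), where compound 2 gives 9810 nM. Going by the values given here, its only neighbour is compound 1 `CC(=O)Oc1ccc(/C=C/C(=O)OCCSc2nc(-c3ccc(S(C)(=O)=O)cc3)n(-c3ccc(C(F)(F)F)cc3)n2)cc1OC(C)=O`, which in this assay gives 14500 nM; the gap a 1.5-fold lower number from compound 1 to compound 2 (0.17 log units; within the scatter) is too small to mean anything, so the two stand together rather than apart.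

Compound 3 `COc1cc(/C=C/C(=O)OCCSc2nc(-c3ccc(S(C)(=O)=O)cc3)n(-c3ccc(C(F)(F)F)cc3)n2)ccc1O` carries one further change: hydrogen in place of acetyl on an oxygen on an aromatic ring. Among the compounds with values here, the only measured step that bears on it is the move from compound 1 to compound 2, where an acetyl on the other ring oxygen was exchanged for methyl and the number barely moved, as a 1.5-fold lower number from compound 1 to compound 2 (0.17 log units; within the scatter) shows. Within the data shown here, that step involved a different replacement on a different oxygen, so it is only a rough guide, but it is the single piece of evidence available, and it points to the acetyl groups on this ring having little effect on the result in this assay.

Compound 3 is therefore expected to stay close to compound 2, with a step of about a 1.1-fold lower number from compound 2 to compound 3 (0.04 log units; within the scatter), and the estimate for compound 3 in this assay is 9000 nM, within a range from 4000 nM to 20000 nM.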

Compound 3, half-maximal inhibitory concentration: 7460 nM
Compound 3: the middle estimate sits 1.2-fold (0.08 log units) above what was measured; the range from low to high includes it.
By their numbers in this assay, from the lowest: compounds 3, 2 and 1 (each within the scatter of the next).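

In this assay, replacing the acetyl on this oxygen with a hydrogen, which turns acetoxy into hydroxy, gives a 1.3-fold lower number from compound 2 to compound 3 (0.12 log units; within the scatter), so the two compounds cannot be told apart at this place. The earlier step exchanged one group for another on a different oxygen, whereas this one removes a group outright: the 4-acetoxy-3-methoxyphenyl group becomes 4-hydroxy-3-methoxyphenyl, and the loss of these 3 heavy atoms still produces no difference beyond the scatter. No measurement shown here accounts for this result, so the data describe only what the assay reads and offer no explanation for it.

From the compounds shown here alone, both steps read so far lie within the scatter, so it remains open whether any replacement on this oxygen can produce a clear difference, for example a longer chain ending in an amine or a carboxylic acid. The compounds shown also share the same core and the same ester chain, so they say nothing about how changes in those parts would affect the number.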